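The compounds below may be only part of what the source reports. "The series", "measured", "known", "first", "only" and "open" are said of these compounds alone.

Compound 1 `CCOc1nc(N)nc2c1ncn2/C=C1/CC1(CO)CO`: > 20000 nM (a limit of the assay, not a number)
Compound 2 `CC(C)CNc1nc(N)nc2c1ncn2/C=C1/CC1(CO)CO`: "not determined" (no result reported)

Both compounds were examined in an ADME assay on MOLT-3 cells (Homo sapiens) for cytotoxicity, with a stated time of 7 days; a lower number here means that less compound is tolerated, a higher number that more compound is tolerated. Compound 2 has no result to place on the scale, as its entry reads "not determined" (no result reported). The only figure available comes from compound 1, which stands at the limit of > 20000 nM in this assay, at which 1 of the 2 values shown sits. That figure is a limit, so it marks no exact level of tolerance.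

The next compound, compound 3 `CCCCOc1nc(N)nc2c1ncn2/C=C1/CC1(CO)CO`, has not yet been measured. The structural change is butoxy in place of isobutylamino on an aromatic carbon. Butoxy takes the place of isobutylamino on an aromatic carbon, next to the ring nitrogen, while the rest of the molecule stays the same.

Among the compounds with values here, no measured step shows what such a swap does in this assay, and compound 2 offers no number to start from. The expectation therefore rests on the limit seen for compound 1, and no step beyond the usual scatter from that level is expected, in either direction. For compound 3 the half-maximal cytotoxic concentration is estimated at 25000 nM, with an expected range of 10000 nM to 60000 nM.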

Compound 3, half-maximal cytotoxic concentration: > 20000 nM
Compound 3: only a limit was reported (the forecaster's own chance of this, stated with the estimate: 65%); the middle value is on the limit's open side.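

In this assay compound 3 gives > 20000 nM as a limit of the assay, not a number. Within the data shown here, compound 1 likewise gives > 20000 nM as a limit, and no step between compound 1 and compound 3 can be read from these two limits. The compounds shown leave open the actual levels of compound 1 and compound 3, and what butoxy in place of isobutylamino does, with compound 2 having no result.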